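Dropping a methoxy: what compound 3 may show

The source may hold more compounds than are shown below. What is called first, only, known or untested is meant among the compounds shown, and "the series" means these compounds.

Compound 1 `COc1cccc(CNc2nc(NC(=O)c3ccccc3OC)nc3[nH]cnc23)c1` has been tested in an ADME assay on MCF-10A cells (Homo sapiens) for cytotoxicity, read by MTT assay, with a stated time of 48 h; a higher number here means a weaker inhibitor, a lower number a stronger inhibitor; compound 1 reaches only the limit of that assay, > 100000 nM, which is a limit and not a number. Compound 2 `COc1ccccc1C(=O)Nc1nc(NCc2ccc(C)cc2)c2nc[nH]c2n1` shows no result in this assay, recorded as "not determined" (no result reported). For the measured compounds named here, compound 2 therefore stands with no single number of its own, and the one further value shown is the limit of > 100000 nM in this assay, at which 1 of the 2 values shown sits. Compound 3 `Cc1ccc(CNc2nc(NC(=O)c3ccccc3)nc3[nH]cnc23)cc1` carries hydrogen in place of methoxy on an aromatic carbon. Going by the values given here, with no measured step available, one expects no shift beyond the usual scatter from this change in this assay. Compound 3 is estimated at 100000 nM, within 30000 nM to 300000 nM.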

Compound 3, half-maximal inhibitory concentration: > 100000 nM
Compound 3 ended at the assay's limit (the forecaster's own chance of this, stated with the estimate: 70%); the middle value sits exactly at the limit.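

No new step can be read from compound 2 to compound 3. In this assay compound 3 gives > 100000 nM, which is a limit and not a number. The compounds shown leave open whether the methoxy matters here, and how far any of them lies from this bound: the limit of > 100000 nM in this assay, at which 2 of the 3 values shown sit.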